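The source may report more compounds than this note shows. Statements on the series, on what has been measured and on what is new or still open speak of the compounds shown alone.

Measured compounds in an assay for inhibition of epoxide hydrolase 1 (Homo sapiens), read by fluorescence, using microsomes; on this read-out higher numbers stand for weaker inhibition and lower numbers for stronger inhibition:
compound 1 `O=C(NC(=S)Nc1ccc(Br)c(C(F)(F)F)c1)c1ccccc1`: 1170 nM
compound 2 `O=C(NC(=S)Nc1ccccc1)c1ccccc1`: 1290 nM
compound 3 `CC(=O)NC(=S)Nc1ccc(Br)c(C(F)(F)F)c1`: 1390 nM

The three numbers sit close together. Compound 1 and compound 3 share a core and differ by methyl in place of phenyl on a carbonyl carbon; this exchange gave a 1.2-fold higher number from compound 1 to compound 3 (0.07 log units; within the scatter). Compound 2 carries a different core from compound 1; the difference between the two cores is not broken down here, and their two values show no separation beyond the scatter. Compound 3 and compound 2 likewise lie within the scatter of each other.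

Compound 4 `CC(=O)NC(=S)Nc1ccccc1` remains to be measured in this assay. It differs from compound 2 by methyl in place of phenyl on a carbonyl carbon, the same change as from compound 1 to compound 3, made at the same place on a carbonyl carbon. The step from compound 2 to compound 4 is expected to be small, a 1.2-fold higher number from compound 2 to compound 4 (0.07 log units; within the scatter), because a 1.2-fold higher number from compound 1 to compound 3 (0.07 log units; within the scatter) showed the exchange to move the number only within the scatter on the core of compound 1. Whether the other core responds alike is not known from these three compounds, so the range is kept wide. Compound 4 is therefore estimated at 1500 nM, between 700 nM and 3300 nM.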

Compound 4, half-maximal inhibitory concentration: 2350 nM
Compound 4: the middle estimate sits 1.6-fold (0.19 log units) below what was measured; the measured number falls inside the stated range.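

In this assay, methyl in place of phenyl on a carbonyl carbon gave a 1.8-fold higher number from compound 2 to compound 4 (0.26 log units; within the scatter), and the same exchange on the other core gave a 1.2-fold higher number from compound 1 to compound 3 (0.07 log units; within the scatter). The two steps do not separate from each other: the same change on two cores in this assay, a 1.2-fold higher number (0.07 log units; within the scatter) from compound 1 to compound 3 and a 1.8-fold higher number (0.26 log units; within the scatter) from compound 2 to compound 4, 1.5-fold (0.19 log units) apart, within the scatter of two such steps

Among the compounds shown here, on these two cores, then, the exchange reads alike and neither step lies beyond the scatter, but this rests on only two pairs and shows neither that the steps are identical nor that the exchange would behave the same way on a further core.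

The compounds shown leave open how a longer chain or an amine would read at the same place on a carbonyl carbon in this assay. They also leave open what bromine and trifluoromethyl each contribute alone, as the two cores differ by both groups together.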